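Swapping methoxy for sulfanyl: an untested step

The source may report more compounds than this note shows. Statements on the series, on what has been measured and on what is new or still open speak of the compounds shown alone.

compound 1 `CCN(CC#CC#CC(C)(C)OC)Cc1cccc(OC[Si](C)(C)c2ccccc2C)c1`: 70 nM
compound 2 `CCN(C/C=C/C#CC(C)(C)C)Cc1cccc(OC[Si](C)(C)c2ccc(C)cc2)c1`: 120 nM
compound 3 `CCN(C/C=C/C#CC(C)(C)C)Cc1cccc(OC[Si](C)(C)c2ccc(OC)cc2)c1`: 870 nM

In a functional assay on liver (Sus scrofa) for inhibition of squalene monooxygenase (Homo sapiens), using microsomes (a lower number here means a stronger inhibitor, a higher number a weaker inhibitor), compound 3 gives 870 nM, the highest of the three numbers. The nearest is compound 2, separated by the step of a 7.3-fold higher number from compound 2 to compound 3 (0.86 log units; beyond the scatter); compound 1 lies further off with 70 nM.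

Compound 4 `CCN(C/C=C/C#CC(C)(C)C)Cc1cccc(OC[Si](C)(C)c2ccc(S)cc2)c1` differs from compound 3 by sulfanyl in place of methoxy on an aromatic carbon. Going by the values given here, no measured step covers this exchange; the only step at the same carbon is a 7.3-fold higher number from compound 2 to compound 3 (0.86 log units; beyond the scatter), which exchanged methyl for methoxy and went beyond the scatter. Whether sulfanyl behaves more like methyl or like methoxy cannot be read from these three compounds, so the expected step of a 1.9-fold lower number from compound 3 to compound 4 (0.29 log units; within the scatter) is modest and uncertain. Compound 4 is therefore estimated at 450 nM, within 120 nM to 1700 nM.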

Compound 4, half-maximal inhibitory concentration: 8000 nM
Compound 4: the middle estimate sits 18-fold (1.25 log units) below what was measured; the whole stated range lies below it.
By their numbers in this assay, from the lowest: compounds 1 and 2 (each within the scatter of the next); then compound 3; then compound 4.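

At this aromatic carbon, para to a large group, sulfanyl in place of methoxy gives a 9.2-fold higher number from compound 3 to compound 4 (0.96 log units; beyond the scatter) in this assay, so the number rises again at the same place. Against methyl the exchange is larger, with a 67-fold higher number from compound 2 to compound 4 (1.82 log units; beyond the scatter) and a step that is beyond the scatter, which separates all three groups at this carbon. Nothing available explains this order of methyl, methoxy and sulfanyl.

As far as these compounds go, whether the sulfur or the hydrogen on it matters more remains open, and methylsulfanyl and hydroxy would bear on that. From the compounds shown here alone, how an amine would read at this carbon also remains unknown.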